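From 3-methoxyphenyl to 4-acetylphenyl in a cell assay

A few compounds are considered here, and "the series" means these few. Any claim that something is new, unique, unknown or untested is made for them only; others in the source may bear on it.

Within the data shown here, in a functional assay on HCT-116 cells (Homo sapiens) for antiproliferative activity, read by MTT assay, with a stated time of 72 h (a higher number here means a weaker inhibitor, a lower number a stronger inhibitor), compound 2 (`COc1cccc(-c2cccc(NC(=O)CCc3cccc4c3COB4O)c2)c1`) gives 46000 nM and compound 1 (`CC(=O)c1ccc(-c2cccc(NC(=O)CCc3ccc4c(c3)COB4O)c2)cc1`) gives 63000 nM as the only other measured value, so the two stand level within the scatter. Compound 3 (`CC(=O)c1ccc(-c2cccc(NC(=O)CCc3cccc4c3COB4O)c2)cc1`) keeps the core of compound 2 and takes 4-acetylphenyl in place of 3-methoxyphenyl on an aromatic carbon, meta to a large group (4-acetylphenyl in place of 3-methoxyphenyl on an aromatic carbon). Among the measured compounds shown here, no measured pair that differs in one place gives a size for this change. In this assay no shift beyond the scatter is expected, because compound 1 with its 4-acetylphenyl group stands at 63000 nM within the scatter of compound 2. The data hold no direct comparison of the two groups on one core, so the range is kept wide. The expected change is a 1.1-fold higher number from compound 2 to compound 3 (0.04 log units; within the scatter) and no larger than the scatter. In this assay compound 3 is estimated at 50000 nM with an expected range running from 22000 nM up to 100000 nM at the outside.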

Compound 3, half-maximal inhibitory concentration: 48000 nM
Compound 3: middle estimate off by 1.0-fold (0.02 log units), on the high side; the range from low to high includes it.
By their numbers in this assay, from the lowest: compounds 2, 3 and 1 (each within the scatter of the next).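

In this assay, among these compounds, the exchange of 3-methoxyphenyl for 4-acetylphenyl on the aromatic carbon gives a 1.0-fold higher number from compound 2 to compound 3 (0.02 log units; within the scatter) and thus supplies the direct comparison of the two groups on one core that the earlier compounds lacked: at this position, on the core of compound 2, they cannot be told apart. Among the compounds shown here, the second step, a 1.3-fold lower number from compound 1 to compound 3 (0.12 log units; within the scatter) in the same assay, adds a first reading at another place, the saturated chain carbon two bonds along the chain from the carbonyl carbon, and shows that the exchange of one group for the other also stays within the scatter when 4-acetylphenyl is held fixed. No measurement on hand bears on why either exchange leaves the number where it is.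

Both steps stay within the scatter, so the compounds shown give no sign of what would move the number in this assay at either place. Still open, on these data alone, is whether an amine or a carboxylic acid on the outer aromatic ring, or a longer chain between the carbonyl carbon and the boron-bearing group, would take the number beyond the scatter.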